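The source may hold more compounds than are shown below. What is called first, only, known or untested is meant among the compounds shown, and "the series" means these compounds.

Measured in a functional assay on HepG2 cells (Homo sapiens) for cytotoxicity, with a stated time of 72 h; on this read-out lower numbers stand for an effect already at smaller amounts and higher numbers for an effect only at larger amounts of compound:
- compound 1, `C=C[C@@](C)(/C=C/c1ccc(Nc2cc(F)cc(F)c2)cc1)CCC=C(C)C`, gives the limit > 52000 nM.
- compound 2, `C=C[C@@](C)(/C=C/c1ccc(Nc2cc(F)c(F)c(F)c2)cc1)CCC=C(C)C`, gives the limit > 52000 nM.
- compound 3, `C=C[C@@](C)(/C=C/c1ccc(-c2ccccc2)cc1)CCC=C(C)C`, gives the limit > 52000 nM.

Compound 2 differs from compound 1 by fluoro in place of hydrogen on an aromatic carbon. The step that the two limits leave unreadable from compound 1 to compound 2 cannot be sized, because of the limit of > 52000 nM in this assay, at which 3 of the 3 values shown sit. Compound 3 differs from compound 1 by phenyl in place of (3,5-difluorophenyl)amino on an aromatic carbon, and the step that the two limits leave unreadable from compound 1 to compound 3 is likewise unreadable for the same reason, (the limit of > 52000 nM in this assay, at which 3 of the 3 values shown sit).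

Compound 4, `C=C[C@@](C)(/C=C/c1ccc(-c2ccc(F)cc2)cc1)CCC=C(C)C`, has not yet been measured in this assay. It differs from compound 3 by fluoro in place of hydrogen on an aromatic carbon. This is the same kind of change as from compound 1 to compound 2, though there the aromatic carbon was also ortho to two fluoro groups. Since the limit of > 52000 nM in this assay, at which 3 of the 3 values shown sit, holds for every measured value, the step from compound 3 to compound 4 is expected to be a step that the limit leaves unreadable from compound 3 to compound 4, with a limit again likely. Compound 4 is estimated at 70000 nM, between 30000 nM and 250000 nM.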

Compound 4, half-maximal effective concentration: > 52000 nM
Compound 4: no number, only a limit; the forecaster's own chance of this, stated with the estimate: 85%; the middle value is on the limit's open side.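

Neither step to compound 4, from compound 3 or from compound 1, can be read, as compound 4 also gives only a limit: the limit of > 52000 nM in this assay, at which 4 of the 4 values shown sit. The compounds shown leave open whether any change on the shared core gives a readable value in this assay.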